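From pentan-3-yl to 2-methoxyethyl on a shared core

The source may report more compounds than this note shows. Statements on the series, on what has been measured and on what is new or still open speak of the compounds shown alone.

Measured in a functional assay (Nicotiana tabacum) (a higher number here means a weaker inhibitor, a lower number a stronger inhibitor), so far
Compound 1 `CCCNc1nc(SC)nc2ncccc12` gives 270 nM
Compound 2 `CSc1nc(NC2CCCCC2)c2cccnc2n1` gives 5650 nM
Compound 3 `CCC(CC)Nc1nc(SC)nc2ncccc12` gives 2720 nM

Compound 3 has the second highest of these three numbers. Its smallest gap is a 2.1-fold lower number from compound 2 to compound 3 (0.32 log units; beyond the scatter) and its widest is a 10-fold higher number from compound 1 to compound 3 (1.00 log units; beyond the scatter) in the same read-out.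

The next compound to be tested is compound 4 `COCCNc1nc(SC)nc2ncccc12` and it has no number yet. It carries 2-methoxyethyl in place of pentan-3-yl on a nitrogen on an aromatic ring.

Within the data shown here, two measured steps bear on this change. Both start from the unbranched propyl chain of compound 1 and both raise the number: a 21-fold higher number from compound 1 to compound 2 (1.32 log units; beyond the scatter) for cyclohexyl and a 10-fold higher number from compound 1 to compound 3 (1.00 log units; beyond the scatter) for pentan-3-yl. Since 2-methoxyethyl is also unbranched, compound 4 should fall closer to compound 1 than to compound 3. None of the three compounds shows what an oxygen in the chain does, so a full return to the number of compound 1 is not assumed and the range stays wide.

The expected change is a 4.5-fold lower number from compound 3 to compound 4 (0.66 log units; beyond the scatter) in this assay as a clear move to a lower number. The estimate for compound 4 is 600 nM (expected range 180 nM to 2000 nM).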

Compound 4, half-maximal inhibitory concentration: 2530 nM
Beside the measured number, compound 4's estimate is 4.2-fold (0.62 log units) below it; the whole stated range lies below it.
By their numbers in this assay, from the lowest: compound 1; then compounds 4 and 3 (each within the scatter of the next); then compound 2.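

In this assay, methoxy in place of methyl on a saturated chain carbon, two bonds along the chain from the nitrogen on the aromatic ring, is a single change that moves the number well away from that of the propyl compound (a 9.4-fold higher number from compound 1 to compound 4 (0.97 log units; beyond the scatter)). An unbranched chain therefore does not by itself keep the number of compound 1, and 2-methoxyethyl and pentan-3-yl, despite their different shapes and atoms, cannot be told apart here (a 1.1-fold lower number from compound 3 to compound 4 (0.03 log units; within the scatter)), while 2-methoxyethyl in place of cyclohexyl gives a smaller step beyond the scatter (a 2.2-fold lower number from compound 2 to compound 4 (0.35 log units; beyond the scatter)). Among these four groups on the nitrogen, propyl alone gives a number far lower than the other three, and no measurement at hand explains this result.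

The compounds shown cannot separate the role of the oxygen from that of the chain as a whole, and butyl, which has a carbon in place of the oxygen of 2-methoxyethyl, would make that comparison directly. From the compounds shown here alone, it also stays open whether chains shorter than propyl, such as ethyl or methyl, would give a number lower than that of compound 1.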